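Chloro step from compound 2 in the series

A few compounds are considered here, and "the series" means these few. Any claim that something is new, unique, unknown or untested is made for them only; others in the source may bear on it.

Measured so far in a functional assay on MCF7 cells (Homo sapiens) for antiproliferative activity, read by MTT assay, with a stated time of 48 h; a higher number here means a weaker inhibitor, a lower number a stronger inhibitor:
compound 1 `O=C(NS(=O)(=O)c1ccccc1)c1cccnc1` gives 14400 nM
compound 2 `Cc1ccc(S(=O)(=O)NC(=O)c2cccnc2)cc1` gives 12000 nM
compound 3 `Cc1ccc(S(=O)(=O)NC(=O)c2cncc(Br)c2)cc1` gives 9370 nM

Compound 2 (12000 nM) holds the middle of these three numbers, and its steps to both neighbours lie within the scatter. Compound 4 `Cc1ccc(S(=O)(=O)NC(=O)c2ccc(Cl)nc2)cc1` is still to be measured in this assay and differs from compound 2 in one place. The change is chloro in place of hydrogen on an aromatic carbon, next to the ring nitrogen and para to a large group.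

Among the compounds with values here, two measured steps bear on it. Swapping a hydrogen for a bromo group gave a small step (a 1.3-fold lower number from compound 2 to compound 3 (0.11 log units; within the scatter)), and methyl in place of hydrogen on an aromatic carbon gave another (a 1.2-fold lower number from compound 1 to compound 2 (0.08 log units; within the scatter)). Neither goes beyond the scatter, so no step beyond the scatter is expected for chloro. The estimated step is small (a 1.2-fold lower number from compound 2 to compound 4 (0.08 log units; within the scatter)). For compound 4 the expected value is 10000 nM within an expected range of 5500 nM to 18000 nM in this series.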

Compound 4, half-maximal inhibitory concentration: 17200 nM
For compound 4 the middle estimate is 1.7-fold (0.24 log units) below the measured one; low and high end bracket the measured number.
By their numbers in this assay, from the lowest: compounds 3, 2, 1 and 4 (each within the scatter of the next).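

In this assay, chloro in place of hydrogen on an aromatic carbon, next to the ring nitrogen and para to a large group, gives a 1.4-fold higher number from compound 2 to compound 4 (0.16 log units; within the scatter) and so stays within the scatter. Within the data shown here, none of the earlier compounds carries a group at this place, so this is the only reading for it: one chlorine atom here leaves the number within the scatter of compound 2. No data at hand bear on what lies behind this step.

The compounds shown leave open whether an amine, a methoxy group or a carboxylic acid at this place would give a step beyond the scatter. Also open, on these data alone, is whether bromo at this place would give a step of similar size to chloro.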